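A few compounds are considered here, and "the series" means these few. Any claim that something is new, unique, unknown or untested is made for them only; others in the source may bear on it.

Working notes on the series. For the measured compounds named here, in a physicochemical assay, with a stated time of 90 min (a higher number here means that more compound is needed for the effect, a lower number that less compound is needed), compound 1 (`C/C(=N\N=C1/SCC(=O)N1Cc1cccc(F)c1)c1cccs1`) gives 1360000 nM and compound 2 (`C/C(=N/N=C1\SCC(=O)N1Cc1ccc(F)cc1)c1cccs1`) gives 1370000 nM with the two values within the scatter of each other, which places compound 1 alongside the only other measured compound. Compound 3 (`C/C(=N\N=C1/SCC(=O)N1Cc1ccccc1F)c1cccs1`) has not yet been measured. Its difference from compound 1 is 2-fluorophenyl in place of 3-fluorophenyl on a saturated chain carbon bound to an amide-type nitrogen in a ring and amounts to 2-fluorophenyl in place of 3-fluorophenyl on a saturated chain carbon bound to an amide-type nitrogen in a ring. Going by the values given here, no step between measured compounds that differ in one place is available, so the data give no direct guide to this change. Resting only on compound 2 at 1370000 nM and its closeness to compound 1, no step beyond the scatter is expected in this assay for this change. The estimated size is a 1.0-fold higher number from compound 1 to compound 3 (0.01 log units; within the scatter) with no direction expected. Compound 3 is estimated at 1400000 nM with an expected range of 700000 nM to 2800000 nM in this measurement.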

Compound 3, half-maximal effective concentration: 1260000 nM
Beside the measured number, compound 3's estimate is 1.1-fold (0.05 log units) above it; the range from low to high includes it.
By their numbers in this assay, from the lowest: compounds 3, 1 and 2 (each within the scatter of the next).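

In this assay the exchange of 3-fluorophenyl for 2-fluorophenyl on a saturated chain carbon bound to an amide-type nitrogen in a ring now has a direct measured step (a 1.1-fold lower number from compound 1 to compound 3 (0.03 log units; within the scatter)). This step lies within the scatter, so the two fluorophenyl groups cannot be told apart at this position in this assay. No measured evidence accounts for this result.

The compounds shown leave open whether a group other than a fluorophenyl at this place, such as a phenyl bearing an amine or a carboxylic acid, would give a step beyond the scatter. They also leave open whether a longer chain between the ring nitrogen and the fluorophenyl would do so.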